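Working notes: changing the group on a carbonyl carbon

The source may report more compounds than this note shows. Statements on the series, on what has been measured and on what is new or still open speak of the compounds shown alone.

Measured so far in a physicochemical assay for solubility; on this read-out higher numbers stand for higher solubility and lower numbers for lower solubility:
- compound 1 `CC(=O)N1CCC[C@H]1C(=O)N1CCC(NS(=O)(=O)c2cc(S(=O)(=O)c3ccccc3)ccc2C(F)(F)F)CC1`: 12500 nM
- compound 2 `O=C([C@@H]1CCCN1C(=O)Nc1ccccc1)N1CCC(NS(=O)(=O)c2cc(S(=O)(=O)c3ccccc3)ccc2C(F)(F)F)CC1`: 25000 nM

Compound 2 at 25000 nM lies within the scatter of compound 1 at 12500 nM, so the two numbers do not separate and neither can be ranked over the other.

The next compound to be read is compound 3 `O=C([C@@H]1CCCN1C(=O)N1CCOCC1)N1CCC(NS(=O)(=O)c2cc(S(=O)(=O)c3ccccc3)ccc2C(F)(F)F)CC1`. It keeps the core of compound 2 and carries morpholin-4-yl in place of anilino on a carbonyl carbon.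

Going by the values given here, only one measured step bears on this change, since it falls at the same place: anilino in place of methyl, a 2.0-fold higher number from compound 1 to compound 2 (0.30 log units; within the scatter). That step stays within the scatter. Among the compounds with values here, no measured compound yet carries morpholin-4-yl, so the data hold no direct evidence for that group, and the single step is thin support.

On this basis, no step beyond the scatter is expected in this assay. The expected change is a 1.3-fold lower number from compound 2 to compound 3 (0.10 log units; within the scatter). For compound 3 the estimated value is 20000 nM, with an expected range of 9000 nM to 45000 nM.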

Compound 3, solubility: 50000 nM
Compound 3: the middle estimate sits 2.5-fold (0.40 log units) below what was measured; the whole stated range lies below it.
By their numbers in this assay, from the lowest: compounds 1, 2 and 3 (each within the scatter of the next, the first and the last beyond it).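

In this assay, this position on the carbonyl carbon now shows its first step beyond the scatter: morpholin-4-yl in place of methyl gives a 4.0-fold higher number from compound 1 to compound 3 (0.60 log units; beyond the scatter), a modest step, whereas anilino in place of methyl did not separate from methyl. Morpholin-4-yl in place of anilino gives a 2.0-fold higher number from compound 2 to compound 3 (0.30 log units; within the scatter), so that pair does not separate, and compound 2 remains within the scatter of both compound 1 and compound 3, with only the two ends of this short series parting. Nothing in the data accounts for any of these steps.

Open, on these data alone, is how a piperidin-1-yl ring, which lacks the ring oxygen of morpholin-4-yl, or an open-chain dimethylamino group would read on this carbonyl carbon, and whether either would separate from morpholin-4-yl or from anilino. Also open, as far as these compounds go, is whether the step from methyl to morpholin-4-yl carries over to a different core, as the three compounds here share one.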